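Compound 2 to compound 4: a naphthalen-2-yl swap

This account rests on a few compounds, and the source may have more. Where it says the series, first, only, none or still open, it means among the compounds named here.

In a functional assay on SW-620 cells (Homo sapiens) for cytotoxicity, read by MTT assay, with stated times of 4 h and 72 h, tested at 1 uM (a higher number here means a weaker inhibitor, a lower number a stronger inhibitor), compound 2 `COc1cc(/C=C/C(=O)c2ccc(Nc3cc(C)nc4nc(SCc5nc6ccccc6[nH]5)nn34)cc2)cc(OC)c1OC` gives 75 nM and lies within the scatter of both measured neighbours. Compound 1 `Cc1cc(Nc2ccc(C(=O)/C=C/c3ccc(Br)cn3)cc2)n2nc(SCc3nc4ccccc4[nH]3)nc2n1` stands at 110 nM and compound 3 `Cc1cc(Nc2ccc(C(=O)/C=C/c3ccc(OC(F)(F)F)c(OC(F)(F)F)c3)cc2)n2nc(SCc3nc4ccccc4[nH]3)nc2n1` at 120 nM on the same read-out, so the three numbers set no order.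

Among the measured compounds shown here, compound 4 `Cc1cc(Nc2ccc(C(=O)/C=C/c3ccc4ccccc4c3)cc2)n2nc(SCc3nc4ccccc4[nH]3)nc2n1` differs from compound 2 by the single change naphthalen-2-yl in place of 3,4,5-trimethoxyphenyl on a double-bonded chain carbon bound to a double-bonded chain carbon and keeps the shared core. The new group, naphthalen-2-yl, sits on a double-bonded chain carbon bound to a double-bonded chain carbon.

For the measured compounds named here, the one measured step at this place is a 1.5-fold lower number from compound 1 to compound 2 (0.17 log units; within the scatter) and it stays within the scatter. Compound 3 carries a third group there, and its number also stays within the scatter of compound 2. Going by the values given here, no measured compound carries naphthalen-2-yl, so the range is kept wide.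

On that evidence the expected change is a 1.3-fold higher number from compound 2 to compound 4 (0.12 log units; within the scatter) and no shift beyond the scatter is expected in this assay in either direction. For compound 4 the estimated value is 100 nM with an expected range from 45 nM to 230 nM in this measurement.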

Compound 4, half-maximal inhibitory concentration: 28.2 nM
Estimate against measurement, compound 4: 3.5-fold (0.55 log units) above; measured number below the stated range.
By their numbers in this assay, from the lowest: compound 4; then compounds 2, 1 and 3 (each within the scatter of the next).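

In this assay, among the compounds shown here, this position now gives steps beyond the scatter, which the earlier compounds at this place did not: a 2.7-fold lower number from compound 2 to compound 4 (0.42 log units; beyond the scatter), and a 3.9-fold lower number from compound 1 to compound 4 (0.59 log units; beyond the scatter). So the group held on a double-bonded chain carbon bound to a double-bonded chain carbon can move this number, although the change from 3,4,5-trimethoxyphenyl to naphthalen-2-yl alters the aromatic ring count and the hydrogen-bond acceptor count together, and the step cannot separate the two. No measured evidence bearing on the cause of this step is at hand.

The compounds shown leave open whether the second aromatic ring of naphthalen-2-yl or the absence of hydrogen-bond acceptors goes with the lower number. They also do not show how a plain phenyl group or a quinolin-3-yl group, which carries a ring nitrogen, would compare at this place.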